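The compounds below may be only part of what the source reports. "The series", "measured", "known", "first", "only" and "open" are said of these compounds alone.

Of the compounds shown here, three built on one shared core have been measured in an ADME assay on WI-38 cells (Homo sapiens) for cytotoxicity, read by MTT assay, with a stated time of 72 h; a higher number here means a weaker inhibitor, a lower number a stronger inhibitor. Compound 1 `O=C(CCc1cccc2c1B(O)OC2)Nc1cccc(I)c1` gives 71000 nM, compound 2 `CC(C)c1cccc(NC(=O)CCc2cccc3c2B(O)OC3)c1` gives 22000 nM, and compound 3 `O=C(CCc1cccc2c1B(O)OC2)Nc1cccc(-c2cccc(OC(F)(F)F)c2)c1` gives 9800 nM. Compound 3 therefore has the lowest number of the three, and its value lies beyond the usual scatter from both of the others.

Compound 4 `CSc1cccc(-c2cccc(NC(=O)CCc3cccc4c3B(O)OC4)c2)c1` differs from compound 3 in a single group, with methylsulfanyl in place of trifluoromethoxy on an aromatic carbon.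

For the measured compounds named here, a pair of compounds differing in one place is the most direct evidence for such a change, and only one measured pair qualifies: a 3.2-fold lower number from compound 1 to compound 2 (0.51 log units; beyond the scatter), with isopropyl in place of iodo on an aromatic carbon. That step is modest and concerns different groups, so it offers a rough size and no direction. Going by the values given here, no measurement yet compares methylsulfanyl with trifluoromethoxy. In this assay, a step no larger than that modest one is therefore expected, and most likely none beyond the scatter. The expected change is a 1.1-fold higher number from compound 3 to compound 4 (0.05 log units; within the scatter). For compound 4 the estimated value is 11000 nM, with an expected range from 5000 nM to 25000 nM.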

Compound 4, half-maximal inhibitory concentration: 2000 nM
For compound 4 the middle estimate is 5.5-fold (0.74 log units) above the measured one; measured number outside the range, below it.
By their numbers in this assay, from the lowest: compound 4; then compound 3; then compound 2; then compound 1.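

In this assay the small group on the outer aromatic ring turns out to matter: methylsulfanyl in place of trifluoromethoxy, on an aromatic carbon of a six-membered aromatic ring of carbon only and meta to a large group, gives a 4.9-fold lower number from compound 3 to compound 4 (0.69 log units; beyond the scatter) and so moves the number by more than the scatter. For the compounds shown here, this is the first comparison of these two groups, and it shows that the change of a single substituent on that ring can shift the reading measurably, even though both groups have no ring and carry the same counts of hydrogen-bond donors and acceptors. Replacing a simple substituent with the whole 3-(methylsulfanyl)phenyl group gives larger steps, with isopropyl as the group replaced in an 11-fold lower number from compound 2 to compound 4 (1.04 log units; beyond the scatter) and iodo as the group replaced in a 36-fold lower number from compound 1 to compound 4 (1.55 log units; beyond the scatter), and nothing available here explains the size or direction of any of these steps.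

From the compounds shown here alone, whether an amine, a carboxylic acid or a longer chain such as ethylsulfanyl at the same place would lower the number further or raise it again remains open. Also open, going by these compounds, is what methylsulfanyl would do directly in place of iodo or isopropyl, without the phenyl ring that carries it in compound 4.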